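The source may hold more compounds than are shown below. What is called first, only, known or untested is meant among the compounds shown, and "the series" means these compounds.

Measured so far:
compound 1, `CC1=NN(C(=O)CN2CCC(Cl)CC2)C(c2ccccc2O)C1`: 34800 nM
compound 2, `O=C(CCl)N1N=C(c2cc3ccccc3oc2=O)CC1c1ccccc1`: 2980 nM

In a functional assay on PC-3 cells (Homo sapiens) for cytotoxicity, read by MTT assay, with a stated time of 48 h (on this read-out lower numbers stand for stronger inhibition and higher numbers for weaker inhibition), compound 2 gives the lowest of the two numbers, with compound 1 a distant second. Compound 3, `CC1CCCN(CC(=O)N2N=C(c3cc4ccccc4oc3=O)CC2c2ccccc2)C1`, differs from compound 2 in one place: 3-methylpiperidin-1-yl in place of chloro on a saturated chain carbon bound to a carbonyl carbon. For the measured compounds named here, no step between measured compounds covers this change, and compound 1, which also carries an amine on the saturated chain carbon bound to the carbonyl, differs from compound 2 elsewhere too. The step from compound 2 to compound 3 is expected to be a moderate weakening, a 3.0-fold higher number from compound 2 to compound 3 (0.48 log units; beyond the scatter). Compound 3 is thus estimated at 9000 nM, within 3000 nM to 30000 nM.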

Compound 3, half-maximal inhibitory concentration: 28300 nM
Compound 3: middle estimate off by 3.1-fold (0.50 log units), on the low side, within the range that was stated.
By their numbers in this assay, from the lowest: compound 2; then compounds 3 and 1 (each within the scatter of the next).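

In this assay, 3-methylpiperidin-1-yl in place of chloro on a saturated chain carbon bound to a carbonyl carbon gives a 9.5-fold higher number from compound 2 to compound 3 (0.98 log units; beyond the scatter) on the shared core. For the compounds shown here, this is the first one-place reading at this position, and it shows that the number here depends on the group carried and that this cyclic amine does not match chloro. No measurement offered here accounts for the size of this step. Going by these compounds, whether a morpholine or a dimethylamino group at this place would stay closer to chloro remains open, as does whether the same replacement would give a similar step on the core of compound 1.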